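Benzisoxazole acid series: aryl ether in place of biphenyl

A few compounds are considered here, and "the series" means these few. Any claim that something is new, unique, unknown or untested is made for them only; others in the source may bear on it.

Compound 2 `O=C(O)c1ccc2noc(-c3cccc(-c4ccccc4)c3)c2c1` is one of two measured members of the series. In an assay for inhibition of inositol hexakisphosphate kinase 2 (Homo sapiens), read by colorimetric assay, coupled enzyme assay and malachite green, with a stated time of 120 min, in the presence of a further agent that is not named here (a lower number here means a stronger inhibitor, a higher number a weaker inhibitor), compound 2 gives 130 nM, while compound 1 `O=C(O)c1ccc2noc(-c3ccc(N4CCCCC4)cc3)c2c1` gives 240 nM; the two numbers lie within the usual scatter of each other, so neither can be ranked ahead of the other. For the measured compounds named here, no pair of measured compounds differs in one place, so no single step has yet been quantified in this assay.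

Compound 3 `O=C(O)c1ccc2noc(-c3cccc(Oc4ncc(Cl)cc4Cl)c3)c2c1` differs from compound 2 by (3,5-dichloropyridin-2-yl)oxy in place of phenyl on an aromatic carbon. Going by the values given here, with no comparable step on record, the direction of the change is open; on the two values in hand, the expectation is a step no larger than the scatter, with the estimated shift given by a 1.2-fold higher number from compound 2 to compound 3 (0.09 log units; within the scatter). In this assay compound 3 is therefore expected to give about 160 nM, with a plausible range from 50 nM to 500 nM.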

Compound 3, half-maximal inhibitory concentration: 71 nM
The estimate for compound 3 lay 2.3-fold (0.35 log units) above the measured number; low and high end bracket the measured number.
By their numbers in this assay, from the lowest: compounds 3, 2 and 1 (each within the scatter of the next, the first and the last beyond it).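

In this assay the exchange of phenyl for (3,5-dichloropyridin-2-yl)oxy gives a 1.8-fold lower number from compound 2 to compound 3 (0.26 log units; within the scatter), so compounds 2 and 3 cannot be ranked against each other. For the compounds shown here, this is the first quantified step, and it shows that this aromatic carbon, meta to a large group, can carry a larger substituent with an oxygen link, a ring nitrogen and two chlorines while the number stays within the scatter of that of compound 2. No measurement on hand bears on what lies behind this step.

The oxygen link, the ring nitrogen and the two chlorines enter together, so their separate contributions cannot be read. A plain phenoxy group, an unsubstituted pyridin-2-yloxy group or an amine link at the same place would separate them.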